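The compounds below may be only part of what the source reports. "The series", "measured", "known", "first", "only" and "open" are said of these compounds alone.

Going by the values given here, compound 1 `CC(C)N(Cc1cccc(OCCCCCC(=O)O)c1)C(=O)c1ccc(-c2cccc(Br)c2)cc1` is one of three compounds tested so far. In an ADME assay on Raji cells (Homo sapiens) for cytotoxicity, read by CellTiter-Glo and resazurin assay, with a stated time of 72 h (a higher number here means that more compound is needed for the effect, a lower number that less compound is needed), compound 1 gives only a limit of the assay, > 26000 nM. Compound 2 `CC(C)N(Cc1cccc(OCCCCCC(=O)O)c1)C(=O)c1ccc(-c2ccc(Cl)c(Cl)c2)cc1` likewise gives only a limit in this assay, > 26000 nM. Compound 3 `CCOC(=O)CCCCCOc1cccc(CN(C(=O)c2ccc(-c3cccc(Br)c3)cc2)C(C)C)c1` also reaches only a limit in this assay, > 26000 nM. The change 3,4-dichlorophenyl in place of 3-bromophenyl on an aromatic carbon therefore made a step that is a step that the two limits leave unreadable from compound 1 to compound 2, and the change ethyl in place of hydrogen on an oxygen next to a carbonyl group made a step that is a step that the two limits leave unreadable from compound 1 to compound 3. Compound 4 `CCOC(=O)CCCCCOc1cccc(CN(C(=O)c2ccc(-c3ccc(Cl)c(Cl)c3)cc2)C(C)C)c1` is not yet measured; it differs from compound 3 by 3,4-dichlorophenyl in place of 3-bromophenyl on an aromatic carbon, the same change as from compound 1 to compound 2, at the same place. The step from compound 3 to compound 4 is expected to be a step that the limit leaves unreadable from compound 3 to compound 4, resting on (the limit of > 26000 nM in this assay, at which 3 of the 3 values shown sit). Compound 4 is estimated to give about 40000 nM in this assay, most likely again only a limit.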

Compound 4, half-maximal effective concentration: > 26000 nM
Compound 4 was reported as a limit; the forecaster's own chance of this, stated with the estimate: 85%; the middle value is on the limit's open side.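

In this assay compound 4 gives only a limit, > 26000 nM, so its steps from compound 3 and compound 2 cannot be read. On these data alone, the concentration giving the effect stays open for all four compounds.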